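The compounds below may be only part of what the source reports. "The series", "measured", "known", "first", "only" and "open" are said of these compounds alone.

Of the compounds shown here, two have been measured in a functional assay on MDA-MB-231 cells (Homo sapiens) for antiproliferative activity, with a stated time of 5 days; on this read-out higher numbers stand for weaker inhibition and lower numbers for stronger inhibition. Compound 1 `O=C1C=CC2(C=C1)OCC(=O)N2c1nc(-c2ccc(F)c3ccccc23)nn1-c1ccccc1` gives 80 nM in this assay, and compound 2 `CC1OC2(C=CC(=O)C=C2)N(c2nc(-c3ccc4ccccc4c3)nn2-c2ccccc2)C1=O` gives 70 nM. Compound 1 has the higher of the two numbers, but its gap to compound 2 lies within the scatter, so the two stand level. Compound 3 `O=C1C=CC2(C=C1)OCC(=O)N2c1nc(-c2cccc(Cl)c2)nn1-c1ccccc1` has not yet been measured in this assay. It differs from compound 1 in a single place: 3-chlorophenyl in place of 4-fluoronaphthalen-1-yl on an aromatic carbon. Going by the values given here, no measured pair shows a step of this kind, so its size must be guessed. A moderate loss is expected in this assay, beyond the scatter but not large, with the step from compound 1 to compound 3 estimated at a 2.5-fold higher number from compound 1 to compound 3 (0.40 log units; beyond the scatter). Compound 3 is therefore expected to give 200 nM, with a range from 50 nM to 800 nM.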

Compound 3, half-maximal inhibitory concentration: 0.8 nM
Compound 3: middle estimate off by 250-fold (2.40 log units), on the high side, outside the stated range (below it).
By their numbers in this assay, from the lowest: compound 3; then compounds 2 and 1 (each within the scatter of the next).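

In this assay, the group on this aromatic carbon of the five-membered aromatic ring with 3 nitrogen proves to be a strong determinant of potency: the change to 3-chlorophenyl from 4-fluoronaphthalen-1-yl gives a 100-fold lower number from compound 1 to compound 3 (2.00 log units; beyond the scatter), a step far beyond the scatter. At this position, then, the second aromatic ring of compound 1 is not required for potent inhibition, as compound 3 reaches a much lower number with one six-membered aromatic ring and fewer heavy atoms. No measurement shown here accounts for the size of this step.

The change replaces the ring system and the halogen together, so the contribution of the chlorine remains unresolved. The compounds shown include no unsubstituted phenyl, 3-fluorophenyl or 3-methoxyphenyl group at this position, and so leave open how much of the gain depends on the chlorine.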